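This account rests on a few compounds, and the source may have more. Where it says the series, first, only, none or still open, it means among the compounds named here.

Measured in an ADME assay on U2OS cells (Homo sapiens) for cytotoxicity; a lower number here means that less compound is tolerated, a higher number that more compound is tolerated:
- compound 1 `O=C(N/N=C/c1ccc([N+](=O)[O-])o1)c1cccs1`: 57200 nM
- compound 2 `O=C(N/N=C/c1ccc([N+](=O)[O-])o1)c1ccc2ccccc2c1`: 64200 nM
- compound 3 `O=C(N/N=C/c1ccc([N+](=O)[O-])o1)C1CCCCC1`: 25400 nM

Of these three compounds, compound 3 has the lowest number, 25400 nM, so less of it is tolerated in this assay. Its gaps to compound 1 and compound 2 both lie beyond the scatter.

The next compound, compound 4 `CCCCCC(=O)N/N=C/c1ccc([N+](=O)[O-])o1`, carries pentyl in place of cyclohexyl on a carbonyl carbon. Among the measured compounds shown here, only one measured step bears on this change, and only indirectly: a 2.3-fold lower number from compound 1 to compound 3 (0.35 log units; beyond the scatter), a modest step that brought in cyclohexyl in place of thiophen-2-yl. For the measured compounds named here, no measured compound carries a group without a ring at this place, so the data give no direction for the exchange. No step beyond the scatter is therefore expected in this assay. The expected change is small, a 1.2-fold higher number from compound 3 to compound 4 (0.07 log units; within the scatter). Compound 4 is estimated at 30000 nM, with an expected range of 14000 nM to 65000 nM.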

Compound 4, half-maximal cytotoxic concentration: 19300 nM
Estimate against measurement, compound 4: 1.6-fold (0.19 log units) above; measured number inside the range.
By their numbers in this assay, from the lowest: compounds 4 and 3 (each within the scatter of the next); then compounds 1 and 2 (each within the scatter of the next).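

In this assay, a group without a ring now stands at this place, on a carbonyl carbon, and pentyl in place of cyclohexyl gives a 1.3-fold lower number from compound 3 to compound 4 (0.12 log units; within the scatter), so in this pair the loss of the ring leaves the number within the scatter. Set against thiophen-2-yl, pentyl gives a 3.0-fold lower number from compound 1 to compound 4 (0.47 log units; beyond the scatter), which places compound 3 and compound 4, the two with no aromatic ring at this place, together at the low end of the four compounds. Nothing given here accounts for these numbers.

As far as these compounds go, whether a longer chain than pentyl, or a chain ending in an amine or a carboxylic acid, would stay with compound 3 and compound 4 remains open. So does the outcome for a smaller saturated ring such as cyclopropyl.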